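Compound 3: chloro in place of hydroxy on the phenyl

This account rests on a few compounds, and the source may have more. Where it says the series, first, only, none or still open, it means among the compounds named here.

Among the measured compounds shown here, compound 2 `CC1=CC[C@H](C(C)(C)NC(=S)N/N=C/c2ccccc2O)CC1` gives 16600 nM in a functional assay on HT-29 cells (Homo sapiens) for inhibition, read by sulforhodamine B assay, with a stated time of 48 h (a lower number here means a stronger inhibitor of growth, a higher number a weaker inhibitor of growth), the only number so far. Compound 1 `CC1=CC[C@H](C(C)(C)NC(=S)N/N=C/c2ccc(O)cc2)CC1` reaches only the assay limit, > 100000 nM. For the measured compounds named here, the single measured comparison is an at least 6.0-fold lower number from compound 1 to compound 2 (0.77 log units; beyond the scatter), its size bounded by the limit of > 100000 nM in this assay, at which 1 of the 2 values shown sits. Compound 3 `CC1=CC[C@H](C(C)(C)NC(=S)N/N=C/c2ccccc2Cl)CC1` differs from compound 2 by chloro in place of hydroxy on an aromatic carbon. Going by the values given here, no measured step exchanges a hydroxy for another group; the one step available concerns only where the hydroxy sits, so it offers no direct guide. Compound 3 is therefore expected to show no step beyond the scatter, a 1.2-fold higher number from compound 2 to compound 3 (0.08 log units; within the scatter), estimated at 20000 nM in this assay, range 5000 nM to 80000 nM.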

Compound 3, concentration for total growth inhibition: > 100000 nM
Compound 3 was reported as a limit; the forecaster's own chance of this, stated with the estimate: 20%; at least 5.0-fold (0.69 log units) between middle value and limit.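

Exchanging the group itself, not only moving the hydroxy, the change from 2-hydroxyphenyl to 2-chlorophenyl gives an at least 6.0-fold higher number from compound 2 to compound 3 (0.77 log units; beyond the scatter) in this assay. At this place on the ring, chloro does not stand in for hydroxy, and among the three compounds only the 2-hydroxyphenyl of compound 2 gives a number. Compound 1 and compound 3 both stand at a limit, so the step between them cannot be read: the limit of > 100000 nM in this assay, at which 2 of the 3 values shown sit.

On these data alone, whether an amine or a methoxy group on the same aromatic carbon would keep a measurable value remains open. As far as these compounds go, the true size of the loss with chloro also remains open.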